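Bicyclic Carbocycle Replaces Spiro Ring on the Amide Carbonyl

The compounds below may be only part of what the source reports. "The series", "measured", "known", "first", "only" and "open" are said of these compounds alone.

Compound 1, `CC1CCC(C(=O)N2CC(c3nc(-c4cccc(Cl)c4)no3)C2)CC1`, gives 1500 nM in an assay on HEK293 cells for positive allosteric modulation of metabotropic glutamate receptor 5 (Homo sapiens), read by FLIPR; a lower number here means that less compound is needed, a higher number that more compound is needed for the effect.
Compound 2, `O=C(N1CCCCCC1)N1CC(c2nc(-c3cccc(Cl)c3)no2)C1`, gives 47 nM in this assay.
Compound 3, `O=C(C1CCC2(CCC2)CC1)N1CC(c2nc(-c3cccc(Cl)c3)no2)C1`, gives 1100 nM in this assay.

Compound 3 holds the second highest of the three numbers in this assay: close to compound 1, as a 1.4-fold lower number from compound 1 to compound 3 (0.13 log units; within the scatter) shows, and far from compound 2, as a 23-fold higher number from compound 2 to compound 3 (1.37 log units; beyond the scatter) shows.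

Compound 4, `O=C([C@H]1CC2CCC1C2)N1CC(c2nc(-c3cccc(Cl)c3)no2)C1`, differs from compound 3 by a group of 7 heavy atoms (7 carbon; 2 five-membered non-aromatic rings of carbon only) in place of a group of 9 heavy atoms (9 carbon; one four-membered non-aromatic ring of carbon only, one six-membered non-aromatic ring of carbon only), on a carbonyl carbon. Within the data shown here, the only measured step that swaps one all-carbon ring group for another is a 1.4-fold lower number from compound 1 to compound 3 (0.13 log units; within the scatter), and it stayed within the scatter. The large steps of a 32-fold lower number from compound 1 to compound 2 (1.50 log units; beyond the scatter) and a 23-fold higher number from compound 2 to compound 3 (1.37 log units; beyond the scatter) each involve the ring nitrogen group of compound 2, so they do not bear on this change. For compound 4 the expected step is therefore a 1.1-fold lower number from compound 3 to compound 4 (0.04 log units; within the scatter), none beyond the scatter. Compound 4 is estimated at 1000 nM in this assay, between 350 nM and 3000 nM.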

Compound 4, half-maximal effective concentration: 74 nM
Estimate against measurement, compound 4: 14-fold (1.13 log units) above; measured number below the stated range.
By their numbers in this assay, from the lowest: compounds 2 and 4 (each within the scatter of the next); then compounds 3 and 1 (each within the scatter of the next).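

On the carbonyl carbon, all-carbon ring groups are clearly not interchangeable in this assay: the group with 2 five-membered rings gives a 15-fold lower number from compound 3 to compound 4 (1.17 log units; beyond the scatter) and a 20-fold lower number from compound 1 to compound 4 (1.31 log units; beyond the scatter). The earlier compounds shown here showed only the azepan-1-yl group of compound 2 reaching a low number, but now a group of carbon alone matches it, with a 1.6-fold higher number from compound 2 to compound 4 (0.20 log units; within the scatter), so a ring nitrogen is not needed here. Nothing measured accounts for the gap among these carbon ring groups. On these data alone, whether the defined stereocentre of compound 4 matters, and whether a piperidine or an open alkyl chain at this place would keep the low number, remains open.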